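Swapping tert-butyl for trifluoromethyl on the shared core

This account rests on a few compounds, and the source may have more. Where it says the series, first, only, none or still open, it means among the compounds named here.

Compound 3 `Cc1ccc(C(=O)C2=C(O)C(=O)N(CC(C)O)C2c2ccc(C(C)(C)C)cc2)cc1` has been measured in an assay on isolated protein for inhibition of annexin A2/S100-A10 (Homo sapiens), with a stated time of 5 min, tested at 50 uM (on this read-out higher numbers stand for more inhibition at the one concentration tested (going by the name of the read-out) and lower numbers for less inhibition), where compound 3 gives 123%. Among the three compounds measured so far, compound 3 holds the highest number. Compound 1 `Cc1ccc(C(=O)C2=C(O)C(=O)N(CC(C)O)C2c2ccc(C(C)C)cc2)cc1` is nearest; in this assay compound 1 gives 101%, and the step between them is a number 22 percentage points higher from compound 1 to compound 3 (beyond the scatter). Compound 2 `CCCc1ccc(C2C(C(=O)c3ccc(C)cc3)=C(O)C(=O)N2CC(C)O)cc1` is furthest; in this assay compound 2 gives 97%, and the step is a number 26 percentage points higher from compound 2 to compound 3 (beyond the scatter). The remaining step, a number 4 percentage points lower from compound 1 to compound 2 (within the scatter), shows that propyl and isopropyl at this position give numbers within the scatter of each other.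

Compound 4 `Cc1ccc(C(=O)C2=C(O)C(=O)N(CC(C)O)C2c2ccc(C(F)(F)F)cc2)cc1` differs from compound 3 at the same aromatic carbon: trifluoromethyl in place of tert-butyl on an aromatic carbon. The two steps that end at compound 3 bear on this change, since both alter the group on that carbon, and both were modest in size. For the measured compounds named here, no measured compound carries trifluoromethyl, so the direction of the new step is uncertain; the measured steps suggest at most a modest move, most plausibly back toward the numbers of compound 1 and compound 2. The step of a number 23 percentage points lower from compound 3 to compound 4 (beyond the scatter) is therefore expected to be a modest fall. Compound 4 is expected to give 100%, with a range from 75% to 125%.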

Compound 4, a percentage reported as inhibition, at one concentration (the size of the read-out at that concentration, not a potency): 102%
Estimate against measurement, compound 4: 2 percentage points below; measured number inside the range.
By their numbers in this assay, from the lowest: compounds 2, 1 and 4 (each within the scatter of the next); then compound 3.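

In this assay, the step of a number 21 percentage points lower from compound 3 to compound 4 (beyond the scatter) shows that at this aromatic carbon the number can change between two groups with the same count of heavy atoms, so that count alone does not set the read-out. Trifluoromethyl also falls in with the straight and branched three-carbon groups, with a number 5 percentage points higher from compound 2 to compound 4 (within the scatter) and a number 1 percentage points higher from compound 1 to compound 4 (within the scatter) both lying within the scatter, which leaves tert-butyl as the only group of the four whose number stands apart. No measurement available here offers an explanation for that difference.

Still open, from the compounds shown here alone, is whether a methoxy group, a chlorine atom, a cyclohexyl ring or a longer chain such as pentyl at this carbon would match tert-butyl or join the other three. The compounds shown also leave open whether moving tert-butyl elsewhere on the same aromatic ring would keep its higher number.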